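Swapping vinyl for fluoro on the sulfonyl ring

The compounds below may be only part of what the source reports. "The series", "measured", "known", "first", "only" and "open" are said of these compounds alone.

Three measured compounds share one core and differ only in the group on the sulfonyl sulfur: compound 1 `O=S(=O)(Nc1ccc(-c2nc3ccccc3o2)cc1)c1cccc(Cl)c1`, compound 2 `O=S(=O)(Nc1ccc(-c2nc3ccccc3o2)cc1)c1ccc(Cl)s1` and compound 3 `C=Cc1ccc(S(=O)(=O)Nc2ccc(-c3nc4ccccc4o3)cc2)cc1`. In an assay on cells for inhibition of HSP60/HSP10 (Homo sapiens), with a stated time of 60 min (a lower number here means a stronger inhibitor, a higher number a weaker inhibitor), compound 1 gives 54000 nM and compound 2 gives 31000 nM. That is a 1.7-fold lower number from compound 1 to compound 2 (0.24 log units; within the scatter). For compound 3 only a limit is known, > 100000 nM, which is the limit of > 100000 nM in this assay, at which 1 of the 3 values shown sits. Compound 4 `O=S(=O)(Nc1ccc(-c2nc3ccccc3o2)cc1)c1ccc(F)cc1` differs from compound 3 by fluoro in place of vinyl on an aromatic carbon. Going by the values given here, the steps that bear on this are an at least 1.8-fold higher number from compound 1 to compound 3 (0.26 log units; that floor lies within the scatter) and an at least 3.2-fold higher number from compound 2 to compound 3 (0.50 log units; beyond the scatter); both moved onto the 4-vinylphenyl and gave a higher number. Moving back off it, to a 4-fluorophenyl that resembles the halogenated rings of compound 1 and compound 2, the expected step is an at least 2.0-fold lower number from compound 3 to compound 4 (0.30 log units; that floor lies within the scatter), a lower number. Compound 4 is accordingly estimated at 50000 nM, with a range from 20000 nM to 150000 nM.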

Compound 4, half-maximal inhibitory concentration: 73000 nM
The estimate for compound 4 lay 1.5-fold (0.16 log units) below the measured number, and the stated range covers the measured number.
By their numbers in this assay, from the lowest: compounds 2, 1 and 4 (each within the scatter of the next, the first and the last beyond it). At a limit, above all of these: compound 3.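

Fluoro in place of vinyl gives an at least 1.3-fold lower number from compound 3 to compound 4 (0.13 log units; that floor lies within the scatter). That step is only a floor, since compound 3 carries just a limit: the limit of > 100000 nM in this assay, at which 1 of the 4 values shown sits. Going by these compounds alone, the 4-fluorophenyl group gives a 1.4-fold higher number from compound 1 to compound 4 (0.13 log units; within the scatter), but also a 2.4-fold higher number from compound 2 to compound 4 (0.37 log units; beyond the scatter), so this is the first phenyl ring with a measured value that stands clearly apart from the 5-chlorothiophen-2-yl group of compound 2.

Still open, from the compounds shown here alone, is how an amine, a carboxylic acid or a longer chain in place of fluoro on this ring would read. Going by these compounds, whether any group here can bring the number far below these values also remains unknown.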